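The compounds below may be only part of what the source reports. "The series", "measured", "known", "first", "only" and "open" are said of these compounds alone.

Compound 1 `COc1cc(-c2nnc(SCC(=O)Nc3ccc(/C(C)=N/O)cc3)n2-c2ccccc2)cc(OC)c1OC` and compound 3 `COc1ccc(-c2nnc(SCC(=O)Nc3ccc(/C(C)=N/O)cc3)n2-c2ccccc2)cc1OC` share a core that differs from the core of compound 2 `CCn1c(SCC(=O)Nc2ccc(C(C)=O)cc2)nnc1-c1ccc(OC)c(OC)c1`; the difference between the two cores is not broken down here. In a functional assay on the whole organism (strain albino) for inhibition, with Rattus norvegicus as the target, read by paw edema, with stated times of 30 min and 3 h, at a dose of 0.28 mmol/kg by the oral route (on this read-out lower numbers stand for less inhibition and higher numbers for more inhibition at the one dose given (going by the name of the read-out)), compound 1 gives 66%. Compound 3 gives 77% in this assay, and the step of a number 11 percentage points higher from compound 1 to compound 3 (beyond the scatter) follows the change (hydrogen in place of methoxy on an aromatic carbon). Compound 2 gives 62% in this assay. Compound 4 `CCn1c(SCC(=O)Nc2ccc(C(C)=O)cc2)nnc1-c1ccc(OC)cc1` has not yet been measured in this assay; it differs from compound 2 by hydrogen in place of methoxy on an aromatic carbon, the same kind of change, though here the place is ortho to a methoxy group and meta to a large group, and not also meta to a methoxy group. Because the step of a number 11 percentage points higher from compound 1 to compound 3 (beyond the scatter) was modest, a step of similar size a number 7 percentage points higher from compound 2 to compound 4 (within the scatter) is expected. Compound 4 is therefore estimated at 69% in this assay, most likely between 55% and 82%.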

Compound 4, a percentage reported as inhibition, in the whole organism at one dose (the size of the read-out at that dose, not a potency): 57%
Beside the measured number, compound 4's estimate is 12 percentage points above it; measured number inside the range.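

On the core of compound 2, hydrogen in place of methoxy (3,4-dimethoxyphenyl to 4-methoxyphenyl) gives a number 5 percentage points lower from compound 2 to compound 4 (within the scatter) in this assay. The same kind of change therefore did not carry over unchanged from one core to the other: the same change on two cores in this assay, a number 11 percentage points higher (beyond the scatter) from compound 1 to compound 3 and a number 5 percentage points lower (within the scatter) from compound 2 to compound 4, 16 percentage points apart, beyond the scatter of two such steps. This rests on a single pair for each core, with the change at a different place on the ring in each pair, and it does not show which difference between the cores or places goes with the gap between the steps.

The compounds shown leave open how a chlorine atom or a hydroxy group in place of the methoxy group would read on either core. They also leave open what a propyl chain in place of the ethyl group of compound 4 would give.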